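A Dimethylfuran Amide Replaces the Halogenated Benzamide

A few compounds are considered here, and "the series" means these few. Any claim that something is new, unique, unknown or untested is made for them only; others in the source may bear on it.

Of the compounds shown here, three with a shared core have been measured in a functional assay on A375P cells (Homo sapiens) for antiproliferative activity, read by MTT assay, with a stated time of 48 h; on this read-out higher numbers stand for weaker inhibition and lower numbers for stronger inhibition. Compound 1 `CC(=O)Nc1cccc2c(-c3cccc(NC(=O)c4cccc(C(F)(F)F)c4)c3)ccnc12` gives 8000 nM. Compound 2 `CC(=O)Nc1cccc2c(-c3cccc(NC(=O)c4ccc(Cl)c(C(F)(F)F)c4)c3)ccnc12` gives 2400 nM, and compound 3 `CC(=O)Nc1cccc2c(-c3cccc(NC(=O)c4cc(Cl)cc(C(F)(F)F)c4)c3)ccnc12` gives 6200 nM. Among these three numbers compound 3 stands second highest: its value and that of compound 1 lie within the scatter of each other, while compound 2 sits clearly lower, as a 2.6-fold higher number from compound 2 to compound 3 (0.41 log units; beyond the scatter) shows. The two chloro additions went in different directions in size: a 3.3-fold lower number from compound 1 to compound 2 (0.52 log units; beyond the scatter), but a 1.3-fold lower number from compound 1 to compound 3 (0.11 log units; within the scatter).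

Compound 4 `CC(=O)Nc1cccc2c(-c3cccc(NC(=O)c4cc(C)oc4C)c3)ccnc12` keeps the shared core and the amide but changes the group on the carbonyl carbon: 2,5-dimethylfuran-3-yl in place of 3-chloro-5-(trifluoromethyl)phenyl on a carbonyl carbon. Going by the values given here, no measured step changes the aryl group on the carbonyl carbon for a heteroaryl, so the only guidance is that swapping one substituted phenyl for another moved this assay by a modest amount, and that dropping substituents here has not helped. The expectation is therefore a somewhat higher number, with wide uncertainty: a 1.6-fold higher number from compound 3 to compound 4 (0.21 log units; within the scatter). Compound 4 is estimated at 10000 nM in this assay, within a range of 3000 nM to 30000 nM.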

Compound 4, half-maximal inhibitory concentration: > 20000 nM
Compound 4 gave a limit, no number; the forecaster's own chance of this, stated with the estimate: 20%; middle value at least 2.0-fold (0.30 log units) away from the limit.
By their numbers in this assay, from the lowest: compound 2; then compounds 3 and 1 (each within the scatter of the next). At a limit, above all of these: compound 4.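

Compound 4 gives a limit in this assay rather than a number: the limit of > 20000 nM in this assay, at which 1 of the 4 values shown sits. Placing 2,5-dimethylfuran-3-yl on the carbonyl carbon gives an at least 3.2-fold higher number from compound 3 to compound 4 (0.50 log units; beyond the scatter) and an at least 2.5-fold higher number from compound 1 to compound 4 (0.39 log units; beyond the scatter) and an at least 8.3-fold higher number from compound 2 to compound 4 (0.92 log units; beyond the scatter) and that last step is larger than any step among the three phenyl amides. The earlier compounds shown here varied only the substituents on a phenyl ring, whereas this result shows that replacing the whole group on the carbonyl carbon weakens inhibition beyond the scatter against each of them, so this position is not indifferent to what sits there.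

The change swaps the ring and its substituents together, so the compounds shown cannot separate the effect of the furan ring from the loss of the trifluoromethyl group. A furan ring carrying a trifluoromethyl group, or a pyridine ring carrying chloro and trifluoromethyl, on the same carbonyl carbon would help to tell these two apart.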